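The compounds below may be only part of what the source reports. "The series", "measured", "known", "first", "only" and "open" are said of these compounds alone.

Measured compounds:
compound 1, `COc1ccc([C@@H]2CC(=O)c3c(O)cc(OCc4cn(Cc5ccc(Cl)cc5)nn4)cc3O2)cc1O`, gives 17800 nM in a functional assay on RAW264.7 cells (Mus musculus) for inhibition, read by Griess assay, with stated times of 2 h and 24 h; a lower number here means a stronger inhibitor, a higher number a weaker inhibitor
compound 2, `COc1ccc([C@@H]2CC(=O)c3c(O)cc(OCc4cn(CCCO)nn4)cc3O2)cc1O`, gives 16700 nM
compound 3, `COc1ccc([C@@H]2CC(=O)c3c(O)cc(OCc4cn(C5CCCCC5)nn4)cc3O2)cc1O`, gives 15600 nM

Compound 1 shows the highest of the three numbers, yet its gaps to compound 2 (a 1.1-fold lower number from compound 1 to compound 2 (0.03 log units; within the scatter)) and to compound 3 (a 1.1-fold lower number from compound 1 to compound 3 (0.06 log units; within the scatter)) both lie within the scatter, so the three compounds cannot be told apart. Compound 4, `COc1ccc([C@@H]2CC(=O)c3c(O)cc(OCc4cn(C)nn4)cc3O2)cc1O`, is not yet measured. It differs from compound 1 by hydrogen in place of 4-chlorophenyl on a saturated chain carbon bound to an aromatic nitrogen. The measured steps that swap the group on the aromatic nitrogen, from compound 1 to compound 2 and from compound 1 to compound 3, stayed within the scatter, and so did a 1.1-fold lower number from compound 2 to compound 3 (0.03 log units; within the scatter). Shrinking that group to its smallest form is therefore expected to give no step beyond the scatter in this assay, that is a 1.0-fold lower number from compound 1 to compound 4 (0.02 log units; within the scatter). Compound 4 is estimated at 17000 nM, within 8000 nM to 36000 nM.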

Compound 4, half-maximal inhibitory concentration: 15200 nM
For compound 4 the middle estimate is 1.1-fold (0.05 log units) above the measured one; measured number inside the range.
By their numbers in this assay, from the lowest: compounds 4, 3, 2 and 1 (each within the scatter of the next).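

In this assay the whole 4-chlorophenyl ring can go, leaving only methyl on the aromatic nitrogen, with no change beyond the scatter (a 1.2-fold lower number from compound 1 to compound 4 (0.07 log units; within the scatter)). Methyl is also indistinguishable from cyclohexyl (a 1.0-fold lower number from compound 3 to compound 4 (0.01 log units; within the scatter)) and from 3-hydroxypropyl (a 1.1-fold lower number from compound 2 to compound 4 (0.04 log units; within the scatter)), so across these four compounds this position shows no preference among the groups tried. No measurement shown explains this flat result. Still open, from the compounds shown here alone, is whether an amine or a carboxylic acid at this position would give a step beyond the scatter.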